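Replacing the Sulfonamide of Compound 1 with a Triazole

The compounds below may be only part of what the source reports. "The series", "measured", "known", "first", "only" and "open" are said of these compounds alone.

For the measured compounds named here, compound 1 `COc1ccc(-c2cc(-c3ccc(S(=O)(=O)N(C)C)cc3)cnc2N)cn1` is the only member of this small set with an actual number in an in vitro ADME assay on microsomes from liver (Homo sapiens) for metabolic stability; a lower number here means slower removal, a higher number faster removal of the compound: compound 1 gives 98.8 mL.min-1.g-1. Compound 2 `COc1ccc(-c2cc(-c3ccc(NS(C)(=O)=O)cc3)cnc2N)cn1` sits at the limit of < 7 mL.min-1.g-1 in this assay, at which 2 of the 3 values shown sit; in this assay compound 2 gives < 7 mL.min-1.g-1, which is a limit of the assay and not a number. Compound 3 `COc1ccc(-c2cc(-c3ccc(S(C)(=O)=O)c(F)c3)cnc2N)cn1` also sits at that limit; in this assay compound 3 gives < 7 mL.min-1.g-1, again a limit. Going by the values given here, the one single-point change measured so far is an at least 14-fold lower number from compound 1 to compound 2 (1.14 log units; beyond the scatter), and it carries compound 2 down to the limit.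

Compound 4 `COc1ccc(-c2cc(-c3ccc(-n4cncn4)cc3)cnc2N)cn1` has not yet been measured. It differs from compound 1 by 1H-1,2,4-triazol-1-yl in place of dimethylsulfamoyl on an aromatic carbon. Among the compounds with values here, the only measured step that starts from the same dimethylsulfamoyl group at the same position, the step from compound 1 to compound 2, was large and downward. The triazolyl entering in compound 4 is a different kind of group from methanesulfonamido, with no hydrogen-bond donor, so the measured step is a guide to direction more than to size. A lower number for compound 4 than for compound 1 is expected, with a step of about a 3.3-fold lower number from compound 1 to compound 4 (0.52 log units; beyond the scatter). Compound 4 is therefore estimated at 30 mL.min-1.g-1, likely falling between 7 mL.min-1.g-1 and 90 mL.min-1.g-1.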

Compound 4, intrinsic clearance in microsomes: 8 mL.min-1.g-1
Beside the measured number, compound 4's estimate is 3.8-fold (0.57 log units) above it, and the stated range covers the measured number.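

The result shows that the high number of compound 1 does not depend on one particular replacement. At this place, on an aromatic carbon para to a large group, 1H-1,2,4-triazol-1-yl gives in this assay a 12-fold lower number from compound 1 to compound 4 (1.09 log units; beyond the scatter) and so joins methanesulfonamido as a second, quite different group that goes the same way, with the count of hydrogen-bond donors staying unchanged between dimethylsulfamoyl and the triazolyl group. Compound 2 carries a limit and not a number, and the comparison with it reads an at least 1.1-fold higher number from compound 2 to compound 4 (0.05 log units; that floor lies within the scatter) and gives no order between these two replacements.

The compounds shown leave open whether a simple amine, a carboxylic acid or a five-membered aromatic ring with fewer hetero atoms would also give so low a number at this place, so how much of the step depends on the triazolyl group itself remains unsettled. With compound 4 now close to the bottom of the read-out, any further gain at this place could hardly be resolved: the limit of < 7 mL.min-1.g-1 in this assay, at which 2 of the 4 values shown sit.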